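The source may hold more compounds than are shown below. What is called first, only, known or untested is meant among the compounds shown, and "the series" means these compounds.

Three compounds share one core and differ only in the group attached to the amide. Compound 1 `CCN(Cc1ccccc1)C(=O)c1nn(-c2ccc(F)cc2)c(OC[C@@H](O)C[C@@H](O)CC(=O)O)c1C(C)C` gives 14 nM in an assay on microsomes from liver for inhibition of 3-hydroxy-3-methylglutaryl-coenzyme A reductase (Rattus norvegicus); on this read-out lower numbers stand for stronger inhibition and higher numbers for weaker inhibition; compound 2 `CC(C)c1c(C(=O)NCC2CCCCC2)nn(-c2ccc(F)cc2)c1OC[C@@H](O)C[C@@H](O)CC(=O)O` gives 17 nM; compound 3 `COc1ccc(CNC(=O)c2nn(-c3ccc(F)cc3)c(OC[C@@H](O)C[C@@H](O)CC(=O)O)c2C(C)C)cc1` gives 12 nM, which on the bare numbers sits at the low end of the three, although the steps of a 1.2-fold lower number from compound 1 to compound 3 (0.07 log units; within the scatter) and a 1.4-fold lower number from compound 2 to compound 3 (0.15 log units; within the scatter) stay within the scatter, as does a 1.2-fold higher number from compound 1 to compound 2 (0.08 log units; within the scatter). Compound 4 `COCc1cccc(CNC(=O)c2nn(-c3ccc(F)cc3)c(OC[C@@H](O)C[C@@H](O)CC(=O)O)c2C(C)C)c1` carries 3-(methoxymethyl)phenyl in place of 4-methoxyphenyl on a saturated chain carbon bound to an amide-type nitrogen. The three measured steps all swap groups at this same place, and none of them moved the number beyond the scatter, so the expected step of a 1.1-fold higher number from compound 3 to compound 4 (0.03 log units; within the scatter) is likewise no change beyond the scatter. Compound 4 is therefore estimated at 13 nM, with a range from 6 nM to 28 nM.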

Compound 4, half-maximal inhibitory concentration: 31 nM
Beside the measured number, compound 4's estimate is 2.4-fold (0.38 log units) below it; measured number outside the range, above it.
By their numbers in this assay, from the lowest: compounds 3, 1, 2 and 4 (each within the scatter of the next, the first and the last beyond it).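

Among the compounds shown here, at this place on the amide, a change can move the number after all: in this assay, 3-(methoxymethyl)phenyl in place of 4-methoxyphenyl gives a 2.6-fold higher number from compound 3 to compound 4 (0.41 log units; beyond the scatter) and (3-(methoxymethyl)benzyl)amino in place of benzyl(ethyl)amino gives a 2.2-fold higher number from compound 1 to compound 4 (0.35 log units; beyond the scatter), the first steps here beyond the scatter. Starting from cyclohexyl, the change gives a 1.8-fold higher number from compound 2 to compound 4 (0.26 log units; within the scatter), so it stands out against only two of the three earlier groups. Nothing measured here explains this shift. Still open, as far as these compounds go, is how 3-methoxyphenyl or 4-(methoxymethyl)phenyl would read at this place, which would separate the effect of the longer methoxymethyl chain from that of its location on the ring.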